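The compounds below may be only part of what the source reports. "The series", "measured", "known", "first", "only" and "open" are said of these compounds alone.

Three compounds that share a core and differ in what sits on the triple bond have been tested in a functional assay on PC-3 cells (Homo sapiens) for antiproliferative activity, read by WST assay, with a stated time of 72 h; a higher number here means a weaker inhibitor of growth, a lower number a stronger inhibitor of growth. Compound 1 `C#Cc1cccc(N/N=N/c2ccc(C(=N)N)cc2)c1` gives 18000 nM, compound 2 `N=C(N)c1ccc(/N=N/Nc2cccc(C#Cc3ccccn3)c2)cc1` gives 10400 nM, and compound 3 `COc1ccc(C#Cc2cccc(N/N=N/c3ccc(C(=N)N)cc3)c2)cc1` gives 5000 nM, the lowest of the three numbers. Compound 4 `N=C(N)c1ccc(/N=N/Nc2cccc(C#Cc3ccccc3)c2)cc1` carries one change from compound 3: hydrogen in place of methoxy on an aromatic carbon, para to a large group (hydrogen in place of methoxy on an aromatic carbon), so that 4-methoxyphenyl becomes phenyl. Among the measured compounds shown here, no measured step makes this exact change. The nearest evidence concerns the group on the triple bond. Exchanging one ring for another there gave only a 2.1-fold lower number from compound 2 to compound 3 (0.32 log units; beyond the scatter), while replacing hydrogen with a ring gave a 3.6-fold lower number from compound 1 to compound 3 (0.56 log units; beyond the scatter) and a 1.7-fold lower number from compound 1 to compound 2 (0.24 log units; within the scatter), the latter within the scatter. Compound 4 keeps a ring there, so only a small drift towards a higher number is expected, not clearly beyond the scatter. The expected step is a 1.5-fold higher number from compound 3 to compound 4 (0.18 log units; within the scatter). For compound 4 the estimated value is 7500 nM, with an expected range from 3000 nM to 16000 nM.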

Compound 4, concentration for 50% growth inhibition: 5800 nM
Compound 4: middle estimate off by 1.3-fold (0.11 log units), on the high side, within the range that was stated.
By their numbers in this assay, from the lowest: compounds 3, 4, 2 and 1 (each within the scatter of the next, the first and the last beyond it).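

Taking the methoxy off gives a 1.2-fold higher number from compound 3 to compound 4 (0.06 log units; within the scatter) in this assay and so does not separate 4-methoxyphenyl from phenyl on the triple bond: at this place on the ring, para to a large group, the methoxy is not needed to keep the number where it stands. Phenyl in place of pyridin-2-yl gives a 1.8-fold lower number from compound 2 to compound 4 (0.25 log units; within the scatter) and so, unlike the 4-methoxyphenyl ring, plain phenyl is not separated from pyridin-2-yl. Phenyl in place of hydrogen gives a 3.1-fold lower number from compound 1 to compound 4 (0.49 log units; beyond the scatter) and shows that a plain phenyl ring on the triple bond is enough for a step beyond the scatter.

As far as these compounds go, whether an amine, a carboxylic acid or a longer chain at this same ring place would move the number remains open. No evidence at hand accounts for these numbers.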